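Swapping Bromo for Fluoro on the Aryl Piperazine

The compounds below may be only part of what the source reports. "The series", "measured", "known", "first", "only" and "open" are said of these compounds alone.

Compound 3 `CCCn1c(=O)[nH]c2nc(-c3ccc(S(=O)(=O)N4CCN(c5ccccc5Br)CC4)cc3)[nH]c2c1=O` gives 20% in an assay on CHO cells for displacement of a labelled ligand from adenosine receptor A3 (Homo sapiens), read by scintillation counting, with a stated time of 45 min, tested at 1 uM, in the presence of a further agent that is not named here (on this read-out lower numbers stand for less inhibition and higher numbers for more inhibition at the one concentration tested (going by the name of the read-out)), the second highest of three numbers. Compound 2 `CCCn1c(=O)[nH]c2nc(-c3ccc(S(=O)(=O)N4CCN(c5ccccc5C)CC4)cc3)[nH]c2c1=O` gives 25%, and compound 1 `CCCn1c(=O)[nH]c2nc(-c3ccc(S(=O)(=O)N4CCN(c5ccc(Cl)cc5F)CC4)cc3)[nH]c2c1=O` gives 14%; both of these sit within the scatter of compound 3, so no order among the three can be claimed. Compound 4 `CCCn1c(=O)[nH]c2nc(-c3ccc(S(=O)(=O)N4CCN(c5ccccc5F)CC4)cc3)[nH]c2c1=O` differs from compound 3 by fluoro in place of bromo on an aromatic carbon. Two measured steps at this place bear on it: a number 5 percentage points lower from compound 2 to compound 3 (within the scatter) and a number 6 percentage points higher from compound 1 to compound 3 (within the scatter), neither beyond the scatter. Only a number 11 percentage points higher from compound 1 to compound 2 (beyond the scatter) exceeded it, and that step replaced the whole 4-chloro-2-fluorophenyl. For compound 4 the expected step is therefore no change at the digits printed from compound 3 to compound 4 (within the scatter), no larger than the scatter. Compound 4 is expected to show 20% in this assay, between 10% and 30%.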

Compound 4, a percentage reported as inhibition, at one concentration (the size of the read-out at that concentration, not a potency): 9%
For compound 4 the middle estimate is 11 percentage points above the measured one; measured number below the stated range.
By their numbers in this assay, from the lowest: compounds 4, 1, 3 and 2 (each within the scatter of the next, the first and the last beyond it).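

At this position the choice of substituent does matter in this assay: fluoro in place of bromo gives a number 11 percentage points lower from compound 3 to compound 4 (beyond the scatter), and fluoro in place of methyl gives a number 16 percentage points lower from compound 2 to compound 4 (beyond the scatter), whereas bromo in place of methyl stayed within the scatter. Hydrogen in place of the chloro of compound 1 gives a number 5 percentage points lower from compound 1 to compound 4 (within the scatter), so that second ring position shows no readable effect here. No measurement at hand accounts for the fluoro result. Going by these compounds, how a methoxy group or a plain phenyl ring would read at this place remains open. These single-concentration numbers also leave potency itself open.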